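A Nitro Group Replaces an Oxadiazole on a Shared Core

This account rests on a few compounds, and the source may have more. Where it says the series, first, only, none or still open, it means among the compounds named here.

Compound 3 `Cc1nnc(-c2cccc(-c3ccc(C(=O)N(Cc4cccc(OCCCCCC(=O)O)c4)C(C)C)cc3)c2)o1` was examined in an ADME assay on HEK293 cells (Homo sapiens) for cytotoxicity, read by CellTiter-Glo and resazurin assay, with a stated time of 72 h; on this read-out higher numbers stand for an effect only at larger amounts of compound and lower numbers for an effect already at smaller amounts. In this assay compound 3 gives only a limit, > 26000 nM. Compound 1 `CC(C)N(Cc1cccc(OCCCCCC(=O)O)c1)C(=O)c1ccc(-c2cccc3ccccc23)cc1` likewise reaches only a limit in this assay, > 26000 nM. Compound 2 `CC(C)N(Cc1cccc(OCCCCCC(=O)O)c1)C(=O)c1ccc(-c2cccc(Oc3ccccc3)c2)cc1` also returns a limit, > 18700 nM. Two of the three values sit at the limit of > 26000 nM in this assay, at which 2 of the 3 values shown sit, and one at the limit of > 18700 nM in this assay, at which 1 of the 3 values shown sits, so compound 3 stands among values that are all limits rather than numbers. The step that the two limits leave unreadable from compound 1 to compound 3 and the step that the two limits leave unreadable from compound 2 to compound 3 therefore cannot be read in size or direction.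

Compound 4 `CC(C)N(Cc1cccc(OCCCCCC(=O)O)c1)C(=O)c1ccc(-c2cccc([N+](=O)[O-])c2)cc1` differs from compound 3 in one place: nitro in place of 5-methyl-1,3,4-oxadiazol-2-yl on an aromatic carbon. Both measured steps that lead to compound 3 are unreadable, so no size or direction can be drawn from them for this change. With every shown value a limit, no step beyond the scatter is expected in this assay, and compound 4 is expected to show a step of a number no higher from compound 3 to compound 4 (the limit leaves the size open). Compound 4 is thus estimated at 26000 nM, expected to lie between 10000 nM and 60000 nM.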

Compound 4, half-maximal effective concentration: > 26000 nM
Compound 4: no number, only a limit; the forecaster's own chance of this, stated with the estimate: 85%; the middle value sits exactly at the limit.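

In this assay compound 4 also gives only a limit (> 26000 nM). Within the data shown here, no step from compound 1, compound 2 or compound 3 to compound 4 can be read. The compounds shown leave open the concentration at which any of them would affect these cells, and whether swapping these groups changes that concentration at all.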